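The compounds below may be only part of what the source reports. "The series", "measured", "known", "first", "only" and "open" are said of these compounds alone.

Compound 3, with the structure `Nc1ccc2cccc(OCC3CCC3)c2n1`, is one of three close relatives built on the same core that have been tested in an assay on cells with melanin-concentrating hormone receptor 1 (Homo sapiens) as the target, read by radioligand binding; on this read-out higher numbers stand for weaker inhibition and lower numbers for stronger inhibition. In this assay compound 3 gives 432 nM. Compound 1, `CC(C)Oc1cccc2ccc(N)nc12`, gives 437 nM, and compound 2, `Nc1ccc2cccc(OCCC3CCCCC3)c2n1`, gives 808 nM; both numbers lie within the usual scatter of compound 3, so the three compounds cannot be told apart on these data. Going by the values given here, the only step that runs between two of them in one place, a 1.0-fold lower number from compound 1 to compound 3 (0.00 log units; within the scatter), is also within the scatter.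

Compound 4, `CCCCOc1cccc2ccc(N)nc12`, has not yet been tested. It differs from compound 3 as follows: propyl in place of cyclobutyl on a saturated chain carbon bound to an oxygen on an aromatic ring. Among the compounds with values here, the one measured step that bears on this, a 1.0-fold lower number from compound 1 to compound 3 (0.00 log units; within the scatter), swapped a branched group for a ring-bearing one at the same oxygen without moving the number. Nothing among the three measured compounds shows a shift beyond the scatter when the group on that oxygen is varied, and a shorter open chain has not been tried. Compound 4 is therefore expected to show a 1.1-fold higher number from compound 3 to compound 4 (0.05 log units; within the scatter), a change no larger than the scatter. The estimate for compound 4 in this assay is 480 nM, with a range from 200 nM to 1200 nM.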

Compound 4, half-maximal inhibitory concentration: 789 nM
For compound 4 the middle estimate is 1.6-fold (0.22 log units) below the measured one, and the stated range covers the measured number.
By their numbers in this assay, from the lowest: compounds 3, 1, 4 and 2 (each within the scatter of the next).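

In this assay, an open butyl chain on the oxygen can stand in for cyclobutylmethyl (a 1.8-fold higher number from compound 3 to compound 4 (0.26 log units; within the scatter)) and for isopropyl (a 1.8-fold higher number from compound 1 to compound 4 (0.26 log units; within the scatter)), and neither exchange moves the number beyond the scatter. The third step, ethyl in place of cyclohexyl on the chain of compound 2 (a 1.0-fold lower number from compound 2 to compound 4 (0.01 log units; within the scatter)), points the same way, so across these four compounds neither a branch nor a ring in the group on this oxygen is shown to matter, and compounds with and without a ring cannot be told apart. No measurement at hand accounts for these small steps.

What the compounds shown leave open is whether any group on this oxygen can move the number clearly at all, for example an amine or a carboxylic acid at the end of the chain, or a longer open chain such as hexyl. They also leave open whether a phenyl ring in place of the saturated rings of compound 2 and compound 3 would give a number beyond the scatter of the others.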